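Trading a carbamate-bearing side chain for isopropyl

The compounds below may be only part of what the source reports. "The series", "measured", "known", "first", "only" and "open" are said of these compounds alone.

Of the compounds shown here, three sharing one core have been tested in a functional assay on L1210 cells (Mus musculus), with a stated time of 12 days; a higher number here means a more potent compound, by a factor of ten per unit of this negative logarithm, a lower number a less potent compound. Compound 1 `CC1=C(N2CC2)C(=O)C(CC(C)OC(N)=O)=C(N2CC2)C1=O` gives 5.79. Compound 2 `CN(C)C(=O)OCCC1=C(N2CC2)C(=O)C(CCOC(=O)N(C)C)=C(N2CC2)C1=O` gives 4.85, and compound 3 `CCCC1=C(N2CC2)C(=O)C(C(COC(N)=O)OC)=C(N2CC2)C1=O` gives 5.07. Compound 1 stands highest of the three: compound 3 lies nearest and compound 2 furthest, both gaps beyond the scatter.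

Compound 4 `CC1=C(N2CC2)C(=O)C(C(C)C)=C(N2CC2)C1=O` has not yet been measured. It differs from compound 1 in one place: a group of 3 heavy atoms (3 carbon; no ring) in place of a group of 7 heavy atoms (4 carbon, 1 nitrogen, 2 oxygen; no ring), on a double-bonded ring carbon The place is a double-bonded ring carbon of the core, next to the ring atom that bears an aziridin-1-yl group.

For the measured compounds named here, no step between measured compounds shows what this change does. The two compounds whose side chains still carry a 7-heavy-atom group of this kind, compound 2 and compound 3, both sit well below compound 1, so the data give no direct guide. The step from compound 1 to compound 4 is expected to be a loss, a number 0.59 log units lower from compound 1 to compound 4 (beyond the scatter), since a group with a hydrogen-bond donor and two acceptors is given up. Compound 4 is therefore expected to reach about 5.2, within a range from 4.6 to 5.8.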

Compound 4, logarithm of the reciprocal of the active concentration, log(1/C): 5.21
Compound 4: the middle estimate sits 0.01 log units below what was measured; the measured number falls inside the stated range.
By their numbers in this assay, from the lowest: compounds 2, 3 and 4 (each within the scatter of the next, the first and the last beyond it); then compound 1.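

Replacing the carbamate-bearing side chain with isopropyl on this double-bonded ring carbon now has a direct reading in this assay: a number 0.58 log units lower from compound 1 to compound 4 (beyond the scatter). The carbamate-bearing chain is therefore linked to higher potency in this one pair, yet it is not needed for activity, since compound 4, with no hydrogen-bond donor or acceptor in that group, still gives 5.21. Nothing measured here explains the drop.

On these data alone, with a single replacement at this place, it remains open whether the number follows the carbamate itself or the chain that carries it. A hydroxyl group on the same chain, an amine, or a longer plain carbon chain such as butyl at this place would help to separate those two readings.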